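The source may report more compounds than this note shows. Statements on the series, on what has been measured and on what is new or still open speak of the compounds shown alone.

Measured so far in an assay on membranes from brain for displacement of a labelled ligand from adenosine receptor A1 (Rattus norvegicus), read by scintillation counting, with a stated time of 90 min; on this read-out lower numbers stand for stronger inhibition and higher numbers for weaker inhibition:
compound 1, `COc1cccc(/C=C/C(=O)Nc2nc3ccccc3c(=O)s2)c1`, gives 205 nM
compound 2, `COc1cccc(CCCC(=O)Nc2nc3ccccc3c(=O)s2)c1`, gives 22.5 nM
compound 3, `O=C(CCCc1cccc(Cl)c1)Nc1nc2ccccc2c(=O)s1`, gives 898 nM

Compound 2 and compound 3 differ in one place, (chloro in place of methoxy on an aromatic carbon); the step is a 40-fold higher number from compound 2 to compound 3 (1.60 log units; beyond the scatter). Compound 1 and compound 2 differ elsewhere, but the difference between the two cores is not broken down here; in this assay compound 1 gives a higher number than compound 2 and a lower number than compound 3.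

Compound 4, `O=C(/C=C/c1cccc(Cl)c1)Nc1nc2ccccc2c(=O)s1`, is not yet measured. It stands to compound 1 as compound 3 stands to compound 2: the change is chloro in place of methoxy on an aromatic carbon, at a place described in the same words, so it is the same change. A large step is expected, a 17-fold higher number from compound 1 to compound 4 (1.23 log units; beyond the scatter), set somewhat short of the one measured, and it rests only on a 40-fold higher number from compound 2 to compound 3 (1.60 log units; beyond the scatter) together with compound 1 at 205 nM. Compound 4 is therefore expected near 3500 nM, in the range 900 nM to 14000 nM.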

Compound 4, inhibition constant: >= 10000 nM
Compound 4 was reported as a limit (the forecaster's own chance of this, stated with the estimate: 12%); middle value at least 2.8-fold (0.45 log units) from the limit.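

In this assay, chloro in place of methoxy also gives a large change on the core of compound 1, with an at least 48-fold higher number from compound 1 to compound 4 (1.68 log units; beyond the scatter). Compound 4 stands at >= 10000 nM, which is a limit of the assay and not a number. The change therefore carries over in the same direction on the two cores shown, but equal size on both is not established: the same change on two cores in this assay, a 40-fold higher number (1.60 log units; beyond the scatter) from compound 2 to compound 3 and an at least 48-fold higher number (1.68 log units; beyond the scatter) from compound 1 to compound 4; the limit leaves it open whether they differ

Going by these compounds, only 3-methoxyphenyl and 3-chlorophenyl are compared on these two cores, so the result for a hydroxy or a fluoro at the same place remains open. Also open, on these data alone, is whether the same change holds on a core with a longer chain.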